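This account rests on a few compounds, and the source may have more. Where it says the series, first, only, none or still open, it means among the compounds named here.

Measured compounds:
compound 1, `CCOC(=O)c1c(-c2cccc(C(F)(F)F)c2)csc1N`, 9.4 uM
compound 2, `Nc1sc(-c2ccc([N+](=O)[O-])cc2)c(-c2cccc(C(F)(F)F)c2)c1C(=O)c1ccccc1`, > 10 uM

In a functional assay on CHO-K1 cells for agonist activity at adenosine receptor A1 (Homo sapiens), read by GTPgammaS binding (on this read-out lower numbers stand for an effect already at smaller amounts and higher numbers for an effect only at larger amounts of compound), compound 1 gives 9.4 uM. Going by the values given here, this is the only number in the set. Compound 2 is reported only as a limit of the assay, > 10 uM. That limit, (the limit of > 10 uM in this assay, at which 1 of the 2 values shown sits), is where one of the two values sits. Among the compounds with values here, compound 1 therefore stands alone as the one compound with a measured number, and nothing in the data ranks it against another compound.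

Compound 3 `CCOC(=O)c1c(N)sc(-c2ccc(C(F)(F)F)cc2)c1-c1cccc(C(F)(F)F)c1` has not yet been measured. It differs from compound 1 in one place: 4-(trifluoromethyl)phenyl in place of hydrogen on an aromatic carbon. Within the data shown here, no step between two measured compounds shows this change, so no measured pair tells how large it is. Compound 2 differs from compound 1 in more than one place, so its value and that of compound 1 can only be set side by side, and the comparison cannot be tied to one change. My expectation for compound 3 is a small step toward activity only at larger amounts, or none beyond the scatter, a 1.6-fold higher number from compound 1 to compound 3 (0.20 log units; within the scatter). Compound 3 is thus estimated at 15 uM, within a range from 4 uM to 50 uM.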

Compound 3, concentration for half-maximal effect: > 10 uM
Compound 3: only a limit was reported; the forecaster's own chance of this, stated with the estimate: 50%; the middle value is on the limit's open side.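

In this assay, compound 3 is reported only as a limit, > 10 uM, and not as a number. Going by these compounds alone, this gives the first single-place reading at this aromatic carbon, next to the ring sulfur: with the rest of compound 1 unchanged, putting 4-(trifluoromethyl)phenyl in place of hydrogen gives an at least 1.0-fold higher number from compound 1 to compound 3 (0.02 log units; that floor lies within the scatter), so the change brings no lower number, but the true size of the step cannot be read. Much of what can be said here rests on that same limit: the limit of > 10 uM in this assay, at which 2 of the 3 values shown sit.

The compounds shown leave open whether a much smaller group on this carbon, such as a methyl group or a chlorine atom, would give a measurable number that can be set against compound 1. They also leave open whether a plain phenyl ring, or a phenyl ring carrying an amine or a carboxylic acid in place of the trifluoromethyl group, would give a lower number or another limit.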